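Shifting a Methyl Group Around a Phenyl Ring

A few compounds are considered here, and "the series" means these few. Any claim that something is new, unique, unknown or untested is made for them only; others in the source may bear on it.

Three compounds have been measured in a functional assay on MCF7 cells (Homo sapiens) for inhibition, read by MTT assay, with a stated time of 24 h, tested at 10 uM; a higher number here means more inhibition of growth at the concentration tested, a lower number less inhibition of growth:
compound 1, `CS(=O)(=O)c1ccc(-c2cnc3[nH]cc(-c4nnc(-c5ccc(Cl)cc5)o4)c(=O)c3c2)cc1`, gives 13.1%;
compound 2, `N#Cc1ccc(-c2cnc3[nH]cc(-c4nnc(-c5ccc(Cl)cc5)o4)c(=O)c3c2)cc1`, gives 19.7%;
compound 3, `Cc1ccc(-c2nnc(-c3c[nH]c4ncc(-c5ccc(S(C)(=O)=O)cc5)cc4c3=O)o2)cc1`, gives 10.6%.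

Compound 3 has the lowest of the three numbers, yet every gap between them lies within the scatter, so the three are not separated. Compound 4, `Cc1cccc(-c2nnc(-c3c[nH]c4ncc(-c5ccc(S(C)(=O)=O)cc5)cc4c3=O)o2)c1`, differs from compound 3 only in this: 3-methylphenyl in place of 4-methylphenyl on an aromatic carbon. Neither measured step touches that part of the molecule. The step of a number 6.6 percentage points higher from compound 1 to compound 2 (within the scatter) and the step of a number 2.5 percentage points lower from compound 1 to compound 3 (within the scatter) each exchange a group elsewhere and each stays within the scatter. Within the data shown here, no measured step moves a methyl around a ring, so nothing beyond the scatter is expected: a number 0.4 percentage points higher from compound 3 to compound 4 (within the scatter). Compound 4 is estimated at 11%, between 3% and 22%.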

Compound 4, percent growth inhibition at one concentration: 7.76%
Compound 4: middle estimate off by 3.2 percentage points, on the high side; measured number inside the range.
By their numbers in this assay, from the lowest: compounds 4, 3, 1 and 2 (each within the scatter of the next, the first and the last beyond it).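

In this assay, among these compounds, moving the methyl, a change no earlier step made, gives a number 2.8 percentage points lower from compound 3 to compound 4 (within the scatter) and so does not separate 3-methylphenyl from 4-methylphenyl at this position. Putting 3-methylphenyl in place of 4-chlorophenyl at the same place gives a number 5.3 percentage points lower from compound 1 to compound 4 (within the scatter) and likewise separates nothing. No outside evidence bears on these numbers.

On these data alone, whether an amine or a carboxylic acid in place of the methyl on this phenyl ring would give a number beyond the scatter remains open. Also open, as far as these compounds go, is whether moving the methyl would do the same with the cyano group of compound 2 in place of methylsulfonyl.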